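Vinyl sulfone series: cytotoxicity on microglial cells

This account rests on a few compounds, and the source may have more. Where it says the series, first, only, none or still open, it means among the compounds named here.

Measured compounds and values:
compound 1 `COc1ccccc1/C=C/S(=O)(=O)c1ccccn1` gives 100%
compound 2 `O=S(=O)(/C=C/c1ccccc1F)c1ccccn1` gives 100%
compound 3 `O=S(=O)(/C=C/c1ccccc1F)c1ncccc1C(F)(F)F` gives 100%

In an ADME assay on BV-2 cells (Mus musculus) for cytotoxicity, with a stated time of 24 h, tested at 10 uM (on this read-out lower numbers stand for a stronger effect and higher numbers for a weaker effect at the one concentration tested), compound 2 stands level with compound 1 and compound 3 at the digits shown. Compound 4 `O=S(=O)(/C=C/c1ccccc1F)c1ccncc1` is not yet measured; the change is pyridin-4-yl in place of pyridin-2-yl on a sulfonyl sulfur. The two measured steps, no change at the digits printed from compound 1 to compound 2 (within the scatter) and no change at the digits printed from compound 2 to compound 3 (within the scatter), both sit within the scatter, though neither touches the sulfonyl sulfur, so nothing directly bears on this change. With every measured value at the same level, compound 4 is expected to show no step beyond the scatter, no change at the digits printed from compound 2 to compound 4 (within the scatter). Compound 4 is therefore estimated at 100%, with a range from 85% to 105%.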

Compound 4, a percentage reported as activity, at one concentration (the size of the read-out at that concentration, not a potency): 100%
Beside the measured number, compound 4's estimate shows no gap at the digits printed, within the range that was stated.
By their numbers in this assay, from the lowest: compounds 1, 2, 3 and 4 (each within the scatter of the next).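

In this assay, the swap of pyridin-2-yl for pyridin-4-yl on the sulfonyl sulfur gives no change at the digits printed from compound 2 to compound 4 (within the scatter). Going by these compounds alone, the earlier steps changed only aromatic carbons, so this is the only direct reading at this position, and here the choice between these two pyridines leaves the read-out unmoved. No supporting measurement bears on this result.

With only these two pyridines shown on the sulfonyl sulfur, the range tolerated at this position remains undefined. Open, on these data alone, is whether a phenyl ring carrying a carboxylic acid, or an amine on a longer chain, would read the same there.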